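The compounds below may be only part of what the source reports. "The series", "measured", "known", "first", "only" and "open" are said of these compounds alone.

Working notes on the series, step from compound 3 to compound 4.

Compound 3 `O=C(/C=C/c1ccc(OCc2cn(Cc3ccccc3Br)nn2)cc1)c1ccc([N+](=O)[O-])cc1` is the reference point here. In a functional assay on MIA PaCa-2 cells (Homo sapiens) for inhibition, read by MTT assay, with a stated time of 48 h, tested at 10 uM (on this read-out higher numbers stand for more inhibition of growth at the one concentration tested and lower numbers for less inhibition of growth), compound 3 gives 34%, the highest of the three numbers recorded so far. Compound 1 `O=C(/C=C/c1ccc(OCc2cn(Cc3ccccc3F)nn2)cc1)c1ccc(Br)cc1` gives 28%, which lies within the scatter of compound 3. Compound 2 `COc1ccc(C(=O)/C=C/c2ccc(OCc3cn(Cc4ccccc4F)nn3)cc2)cc1` gives 19%, and that gap to compound 3 lies beyond the scatter.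

Within the data shown here, the one measured step between single-point neighbours is a number 9 percentage points lower from compound 1 to compound 2 (within the scatter), methoxy in place of bromo on the aryl ketone side, and it stays within the scatter. Among the measured compounds shown here, no measured pair changes the halogen on the benzyl group; compounds 1 and 2 both carry the fluoro there, compound 3 the bromo, and these compounds differ elsewhere as well, so their values say nothing clean about this position on their own.

Compound 4 `O=C(/C=C/c1ccc(OCc2cn(Cc3ccccc3F)nn2)cc1)c1ccc([N+](=O)[O-])cc1` differs from compound 3 by fluoro in place of bromo on an aromatic carbon. For the measured compounds named here, with no step in hand that bears directly on this change, and the only measured step being small, no movement beyond the scatter is expected in this assay . The estimate for compound 4 is 31%, with a range of 19% to 44%. The expected step is a number 3 percentage points lower from compound 3 to compound 4 (within the scatter).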

Compound 4, percent growth inhibition at one concentration: 22%
Estimate against measurement, compound 4: 9 percentage points above; low and high end bracket the measured number.
By their numbers in this assay, from the lowest: compounds 2, 4, 1 and 3 (each within the scatter of the next, the first and the last beyond it).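

In this assay, the halogen on the benzyl group gets its first clean reading: a number 12 percentage points lower from compound 3 to compound 4 (beyond the scatter), so 2-fluorobenzyl in place of 2-bromobenzyl is a change this assay can register when the nitro group on the aryl ketone side is held constant. With the 2-fluorobenzyl group held constant, the aryl ketone side now has three members, and neither new step leaves the scatter: a number 3 percentage points higher from compound 2 to compound 4 (within the scatter) and a number 6 percentage points lower from compound 1 to compound 4 (within the scatter), so among the single-place steps in hand, only the halogen change on the benzyl group goes beyond it. No independent data bear on the origin of this step.

Among these compounds, whether the same halogen change gives a step of similar size with a bromo or methoxy group on the aryl ketone side stays open, as the only matched pair carries the nitro group. Also open, from the compounds shown here alone, is how a chloro or methyl group on the benzyl ring, or an amine or carboxylic acid on the aryl ketone side, would read in this assay.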